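This account rests on a few compounds, and the source may have more. Where it says the series, first, only, none or still open, it means among the compounds named here.

Compound 1 `O=C(CCCCCCCCc1ccccc1)N1CCCCC1` gives > 100000 nM
Compound 2 `O=C(CCCCCCCCc1ccccc1Cl)N1CCCCC1` gives > 100000 nM

Both values come from a functional assay on PANC-1 cells (Homo sapiens) for cytotoxicity, read by WST assay, with a stated time of 24 h (a lower number here means a stronger inhibitor, a higher number a weaker inhibitor), and both are limits of the assay, not numbers. Compound 2 stands at > 100000 nM, a limit. It shares this with compound 1, as the limit of > 100000 nM in this assay, at which 2 of the 2 values shown sit, shows. Among the compounds with values here, the one measured step is a step that the two limits leave unreadable from compound 1 to compound 2, so the data give no size for a change on this aromatic ring.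

Compound 3 `O=C(CCCCCCCCc1cccc(Cl)c1)N1CCCCC1` moves the chlorine and changes nothing else: 3-chlorophenyl in place of 2-chlorophenyl on a saturated chain carbon, eight bonds along the chain from a carbonyl carbon. In words, 3-chlorophenyl replaces 2-chlorophenyl on a saturated chain carbon, eight bonds along the chain from a carbonyl carbon. With no readable step to build on, nothing points to a change beyond the scatter in this assay, and another limit is the likeliest report. The expected size is a number no higher from compound 2 to compound 3 (the limit leaves the size open), with no direction favoured. For compound 3 the estimate is 100000 nM, with an expected range from 40000 nM to 200000 nM.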

Compound 3, half-maximal inhibitory concentration: > 100000 nM
Compound 3: a limit, no number (the forecaster's own chance of this, stated with the estimate: 80%); the middle value sits exactly at the limit.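

Within the data shown here, compound 3 gives only a limit of the assay, not a number, as do compound 1 and compound 2, so no step among the three can be read: the limit of > 100000 nM in this assay, at which 3 of the 3 values shown sit. The compounds shown leave open whether the chlorine, or where it sits on the ring, affects this assay at all.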